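A few compounds are considered here, and "the series" means these few. Any claim that something is new, unique, unknown or untested is made for them only; others in the source may bear on it.

Among the measured compounds shown here, compound 2 `COc1ccnc(-c2cnc(C(=O)CCCCCCc3ccccc3)o2)c1` gives 0.8 nM in an assay (Rattus norvegicus) for inhibition of Fatty-acid amide hydrolase 1 (Homo sapiens) (a lower number here means a stronger inhibitor, a higher number a weaker inhibitor), the lowest of the two numbers so far; compound 1 `COc1ccccc1-c1cnc(C(=O)CCCCCCc2ccccc2)o1` gives 400 nM there. For the measured compounds named here, the only step measured at the aromatic carbon that carries the aryl group, a 500-fold lower number from compound 1 to compound 2 (2.70 log units; beyond the scatter), shows how strongly that group governs this assay. Compound 3 `NS(=O)(=O)c1ccc(-c2cnc(C(=O)CCCCCCc3ccccc3)o2)s1` carries 5-sulfamoylthiophen-2-yl in place of 4-methoxypyridin-2-yl on an aromatic carbon. Going by the values given here, no measured step covers a sulfamoylthiophene here, so the step is expected to be sizeable and toward a higher number, given that compound 2 already gives 0.8 nM. Compound 3 is estimated at 20 nM (range 2 nM to 200 nM), meaning a 25-fold higher number from compound 2 to compound 3 (1.40 log units; beyond the scatter) is expected.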

Compound 3, inhibition constant: 3 nM
For compound 3 the middle estimate is 6.7-fold (0.82 log units) above the measured one; low and high end bracket the measured number.
By their numbers in this assay, from the lowest: compound 2; then compound 3; then compound 1.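

In this assay, a five-membered aromatic ring also serves at this position: 5-sulfamoylthiophen-2-yl in place of 4-methoxypyridin-2-yl gives only a 3.8-fold higher number from compound 2 to compound 3 (0.57 log units; beyond the scatter) and so keeps most of the large gain seen against 2-methoxyphenyl, with a 130-fold lower number from compound 1 to compound 3 (2.12 log units; beyond the scatter). A low number is therefore not tied to the 4-methoxypyridin-2-yl group alone, and among the three compounds, compound 1 stands apart. No data are at hand to explain these differences.

Ring and substituent change together here, so their separate shares remain open. A thiophene bearing a carboxylic acid in place of the sulfamoyl group, or an unsubstituted pyridin-2-yl, would begin to separate them.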